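Swapping an imidazolylethoxy arm for a sulfamoyl group

A few compounds are considered here, and "the series" means these few. Any claim that something is new, unique, unknown or untested is made for them only; others in the source may bear on it.

Measured so far:
compound 1 `c1ccc(-c2ccnc(Nc3cccc(OCCn4ccnc4)c3)n2)nc1`: 400 nM
compound 2 `c1cc(Nc2nccc(-c3cccs3)n2)cc(OCCn2ccnc2)c1`: 100 nM

In a functional assay for inhibition, with Homo sapiens as the target (on this read-out higher numbers stand for weaker inhibition and lower numbers for stronger inhibition), compound 1 gives 400 nM, the highest of the two numbers; its nearest neighbour is compound 2, which shows a 4.0-fold lower number from compound 1 to compound 2 (0.60 log units; beyond the scatter). Compound 3 `NS(=O)(=O)c1cccc(Nc2nccc(-c3ccccn3)n2)c1` is not yet measured. It differs from compound 1 by sulfamoyl in place of 2-(1H-imidazol-1-yl)ethoxy on an aromatic carbon. Among the compounds with values here, the one measured step, from compound 1 to compound 2, changes a different ring and so says nothing about this swap. Within the data shown here, with no comparable step available, no shift beyond the scatter is expected for compound 3, though the uncertainty is wide: the estimate is 300 nM (60 nM to 1500 nM), an expected step of a 1.3-fold lower number from compound 1 to compound 3 (0.12 log units; within the scatter).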

Compound 3, half-maximal inhibitory concentration: 500 nM
Beside the measured number, compound 3's estimate is 1.7-fold (0.22 log units) below it; low and high end bracket the measured number.
By their numbers in this assay, from the lowest: compound 2; then compounds 1 and 3 (each within the scatter of the next).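

Sulfamoyl in place of 2-(1H-imidazol-1-yl)ethoxy gives a 1.3-fold higher number from compound 1 to compound 3 (0.10 log units; within the scatter) in this assay and so lies within the scatter. With compound 1 as the starting point, this place therefore accepts a group with no ring and fewer heavy atoms, so the five-membered aromatic ring is not required to keep this level of inhibition. Nothing available explains why the two groups read alike.

From the compounds shown here alone, whether sulfamoyl matches the imidazolylethoxy arm alongside the thiophen-2-yl of compound 2 remains open. So does how an amine, a carboxylic acid or a longer chain would read at this place.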